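This account rests on a few compounds, and the source may have more. Where it says the series, first, only, none or still open, it means among the compounds named here.

Measured so far in an ADME assay on microsomes from liver (Homo sapiens) for metabolic stability; on this read-out lower numbers stand for slow clearance and higher numbers for fast clearance:
- compound 1 `O=C(O)CCNC(=O)c1ccc(C(Oc2ccc(-n3cc(C(F)(F)F)cn3)cc2)C2CC2)cc1`: < 8 mL/min/kg
- compound 2 `CCCC(Oc1ccc(-n2cc(C#N)cn2)cc1)c1ccc(C(=O)NCCC(=O)O)cc1`: < 8 mL/min/kg

Compound 1 gives < 8 mL/min/kg, which is a limit and not a number. Compound 2 also gives a limit, < 8 mL/min/kg. Among the measured compounds shown here, the series so far therefore rests on (the limit of < 8 mL/min/kg in this assay, at which 2 of the 2 values shown sit), and no exact value is available for either compound.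

Compound 3 `CC(C)(C)C(Oc1ccc(-n2cc(C(F)(F)F)cn2)cc1)c1ccc(C(=O)NCCC(=O)O)cc1` carries tert-butyl in place of cyclopropyl on a saturated chain carbon bound to an aromatic carbon and an oxygen on an aromatic ring. For the measured compounds named here, no measured step in this assay covers this change. No step beyond the scatter is expected, and any small movement is expected toward higher clearance. The expected step is a step that the limit leaves unreadable from compound 1 to compound 3. For compound 3 the estimated clearance is 7 mL/min/kg, with an expected range of 4 mL/min/kg to 14 mL/min/kg.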

Compound 3, clearance: 31 mL/min/kg
Beside the measured number, compound 3's estimate is 4.4-fold (0.65 log units) below it; measured number outside the range, above it.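

In this assay, the saturated chain carbon bound to an aromatic carbon and an oxygen on an aromatic ring proves sensitive to its substituent: tert-butyl in place of cyclopropyl gives an at least 3.8-fold higher number from compound 1 to compound 3 (0.58 log units; beyond the scatter). Compound 1 gives < 8 mL/min/kg, which is a limit of the assay. The full size of the step cannot be read, because the low end of the series rests on a limit: the limit of < 8 mL/min/kg in this assay, at which 2 of the 3 values shown sit.

This single pair does not separate the loss of the three-membered ring from the gain of a fourth carbon. On these data alone, whether isopropyl or cyclobutyl at this place stays at the limit or climbs as tert-butyl does remains open, as does whether the same change raises clearance with a nitrile in place of trifluoromethyl.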